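A few compounds are considered here, and "the series" means these few. Any claim that something is new, unique, unknown or untested is made for them only; others in the source may bear on it.

Working notes on the urea series. Compound 1 `COc1cccc(NC(=O)N[C@@H](C)c2ccccc2)c1` gives in an ADME assay on the whole organism with Oryza sativa as the target, tested at 1 uM (a lower number here means a stronger effect, a higher number a weaker effect of the compound at the concentration tested), a reading of 99%. Among the measured compounds shown here, compound 2 `C[C@@H](NC(=O)Nc1cccc(I)c1)c1ccccc1` gives in this assay a reading of 75%, the lowest of the two numbers measured so far, and compound 1 stands above it by a gap that is beyond the usual scatter. The step considered next leads from compound 2 to compound 3 `C[C@H](NC(=O)Nc1cccc(I)c1)c1ccccc1`, with this change: the two compounds have the same atoms and bonds and differ only in configuration as drawn: 1 of 1 stereo elements differ; a stereocentre at a saturated chain carbon is drawn R in compound 2 and S in compound 3. For the measured compounds named here, no pair of measured compounds shows what such a change at the stereocentre does in this assay, so the size and direction of the step are open. In this assay compound 3 is expected to move by a number 3 percentage points higher from compound 2 to compound 3 (within the scatter), a step not clearly beyond the scatter in either direction. Compound 3 is therefore estimated at 78% in this assay, within a range from 55% to 100%.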

Compound 3, a percentage reported as activity, at one concentration (the size of the read-out at that concentration, not a potency): 95%
Estimate against measurement, compound 3: 17 percentage points below, within the range that was stated.
By their numbers in this assay, from the lowest: compound 2; then compounds 3 and 1 (each within the scatter of the next).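

In this assay the stereocentre at the saturated chain carbon matters with the iodo group in place, with a number 20 percentage points higher from compound 2 to compound 3 (beyond the scatter). The change of configuration alone accounts for this step: the fact that compounds 2 and 3 differ only in the configuration as drawn. Iodo in place of methoxy on an aromatic carbon, with the stereocentre drawn the same way in both compounds, gives a number 4 percentage points lower from compound 1 to compound 3 (within the scatter), so among these compounds the lower reading of compound 2 goes with the R drawing and not with iodo as such.

Going by these compounds, it remains open whether the same configuration step appears with methoxy on the aromatic carbon, or only with iodo. Also open, on these data alone, is how the R and S drawings compare with a different group at that carbon, such as an amine or a carboxylic acid, or with a longer chain at the stereocentre.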